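Swapping the aromatic substituent for a branched alkyl chain

The source may report more compounds than this note shows. Statements on the series, on what has been measured and on what is new or still open speak of the compounds shown alone.

Compound 2 `COc1cccc(CNCCCNc2ccnc3cc(-c4ccc(C(F)(F)F)cc4)ccc23)c1O` sits level with compound 1 `COc1cccc(CNCCCNc2ccnc3cc(Cc4ccccc4)ccc23)c1O` in a physicochemical assay for acid dissociation: compound 1 gives 9.47 and compound 2 gives 9.47. Going by the values given here, the one measured step, no change at the digits printed from compound 1 to compound 2 (within the scatter), exchanged one group on that same aromatic carbon of the shared core and left the read-out untouched within the scatter.

Compound 3 `CCC(CC)c1ccc2c(NCCCNCc3cccc(OC)c3O)ccnc2c1` differs from compound 2 at exactly that position: pentan-3-yl in place of 4-(trifluoromethyl)phenyl on an aromatic carbon. Among the compounds with values here, the only step that bears on it is the one from compound 1 to compound 2, and it was flat. No other measurement speaks to this position, so the expectation is that the step from compound 2 to compound 3 in this assay is no change at the digits printed from compound 2 to compound 3 (within the scatter), that is, nothing beyond the scatter.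

Compound 3 is therefore estimated at 9.47, with a range from 9.15 to 9.8.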

Compound 3, acid dissociation constant: 9.47
Beside the measured number, compound 3's estimate shows no gap at the digits printed, within the range that was stated.
By their numbers in this assay, from the lowest: compounds 1, 2 and 3 (each within the scatter of the next).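

The earlier step exchanged one ring-bearing group for another, whereas pentan-3-yl has no ring and no fluorine and is a smaller group than 4-(trifluoromethyl)phenyl. Even so, in this assay this change gives no change at the digits printed from compound 2 to compound 3 (within the scatter), and the exchange for benzyl gives no change at the digits printed from compound 1 to compound 3 (within the scatter). Across these three compounds, then, the read-out does not depend on a ring in the group on this aromatic carbon, although no measurement here explains why.

Neither pentan-3-yl nor 4-(trifluoromethyl)phenyl has a hydrogen-bond donor or acceptor, so these compounds do not show how a group carrying either would behave at this position. As far as these compounds go, whether an amine or a carboxylic acid on this aromatic carbon would shift the value beyond the scatter remains open.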